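Bromo for methyl on the thiazole of a glutamate receptor antagonist

The compounds below may be only part of what the source reports. "The series", "measured", "known", "first", "only" and "open" are said of these compounds alone.

The measured compounds and their values:
compound 1 `Cc1nc(C#Cc2cccc(F)c2)cs1` 23 nM
compound 2 `COc1cccc(C#Cc2csc(C)n2)c1` 49 nM

In a functional assay on CHO cells for agonist activity at metabotropic glutamate receptor 5 (Homo sapiens), read by inositol phosphate accumulation (a lower number here means a stronger inhibitor, a higher number a weaker inhibitor), compound 1 gives 23 nM, the lowest of the two numbers; its nearest neighbour is compound 2, which gives 49 nM. Within the data shown here, the only measured step, a 2.1-fold higher number from compound 1 to compound 2 (0.33 log units; beyond the scatter), concerns an exchange on the benzene ring and is modest. Compound 3 `Fc1cccc(C#Cc2csc(Br)n2)c1` is unmeasured. It differs from compound 1 by bromo in place of methyl on an aromatic carbon. Among the measured compounds shown here, no measured step touches this place, so the single step to hand says nothing direct about the exchange of methyl for bromo; it shows only that a one-atom swap elsewhere in the shared core moved the number by a modest amount. Compound 3 is therefore expected to stay close to compound 1, with a step of a 1.7-fold higher number from compound 1 to compound 3 (0.24 log units; within the scatter), and its estimated value is 40 nM, in the range 12 nM to 130 nM.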

Compound 3, half-maximal inhibitory concentration: 526 nM
Beside the measured number, compound 3's estimate is 13-fold (1.12 log units) below it; the measured number lies above the stated range.
By their numbers in this assay, from the lowest: compound 1; then compound 2; then compound 3.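

In this assay, among these compounds, this place on the core turns out to be far more sensitive than the earlier compounds could show: bromo in place of methyl on the aromatic carbon next to the ring nitrogen and next to the ring sulfur gives a large weakening (a 23-fold higher number from compound 1 to compound 3 (1.36 log units; beyond the scatter)), against only a modest one for methoxy in place of fluoro (a 2.1-fold higher number from compound 1 to compound 2 (0.33 log units; beyond the scatter)). Methyl and bromo have the same count of heavy atoms, and neither brings a hydrogen-bond donor, a hydrogen-bond acceptor or a net charge, so these counts do not account for the gap between compound 1 and compound 3. Nothing available explains why this exchange costs so much.

On these data alone, whether the loss is particular to bromo, or would also follow from chloro, ethyl or an amine at this place, remains open. Also open, as far as these compounds go, is whether bromo would cost as much with methoxy in place of fluoro.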